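This account rests on a few compounds, and the source may have more. Where it says the series, first, only, none or still open, it means among the compounds named here.

Measured so far:
- Compound 1, `Cc1cc(C)c(S(=O)(=O)N2CCC(N3CCC(C)CC3)CC2)c(C)c1`: 0.03 nM
- Compound 2, `Cc1cc(C)c(S(=O)(=O)N2CCC(N3CCC(O)CC3)CC2)c(C)c1`: 106 nM

In a functional assay on DLD-1 cells (Homo sapiens) for antiproliferative activity, read by CellTiter-Glo, with a stated time of 72 h (on this read-out higher numbers stand for weaker inhibition and lower numbers for stronger inhibition), compound 2 stands highest of the two numbers; its nearest neighbour is compound 1, and the step of a 3500-fold higher number from compound 1 to compound 2 (3.55 log units; beyond the scatter) separates them. Within the data shown here, the only change along that step is a 3500-fold higher number from compound 1 to compound 2 (3.55 log units; beyond the scatter) in structure terms: hydroxy in place of methyl on a saturated ring carbon. Compound 3, `Cc1cc(C)c(S(=O)(=O)N2CCC(C(=O)N3CCC(C)CC3)CC2)c(C)c1`, carries the change ((4-methylpiperidin-1-yl)carbonyl in place of 4-hydroxypiperidin-1-yl on a saturated ring carbon). Here the methyl on the outer saturated ring returns, which is the part of the move that the step from compound 1 to compound 2 speaks to, but a carbonyl also enters, and no measured pair shows the effect of that insertion. A large downward step is therefore expected in this assay, though with wide uncertainty. For compound 3 the estimate is 3 nM, ranging from 0.1 nM to 100 nM, which is expected to mean a step of a 35-fold lower number from compound 2 to compound 3 (1.55 log units; beyond the scatter).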

Compound 3, half-maximal inhibitory concentration: > 5000 nM
Compound 3 was reported as a limit; the forecaster's own chance of this, stated with the estimate: 5%; at least 1600-fold (3.22 log units) between middle value and limit.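

In this assay compound 3 gives > 5000 nM, which is a limit of the assay and not a number. The methyl on the outer ring therefore does not bring the activity back once a carbonyl enters, and the move is an at least 47-fold higher number from compound 2 to compound 3 (1.67 log units; beyond the scatter), so compound 3 ends up weaker than the hydroxy compound rather than close to the methyl compound. The clearest reading is an at least 160000-fold higher number from compound 1 to compound 3 (5.22 log units; beyond the scatter), where the 4-methylpiperidin-1-yl group stays and the carbonyl is the new element, and this loss is larger than a 3500-fold higher number from compound 1 to compound 2 (3.55 log units; beyond the scatter).

On these data alone, whether a methylene in place of the carbonyl would hold the activity of compound 1 remains open. Also open, as far as these compounds go, is how the outer ring responds to other groups, such as a fluorine or a methoxy, since only methyl and hydroxy appear there.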